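One Added Chloro and the Reading It May Bring

A few compounds are considered here, and "the series" means these few. Any claim that something is new, unique, unknown or untested is made for them only; others in the source may bear on it.

Within the data shown here, in a functional assay on LoVo cells (Homo sapiens) for inhibition, read by colorimetric assay and MTT assay, with a stated time of 72 h (on this read-out higher numbers stand for weaker inhibition and lower numbers for stronger inhibition), compound 1 `C=CCCCCOc1ncc(-c2ccccc2OC)n1C` gives 4000 nM and so holds the lower of the two numbers measured so far. Its chlorinated relative, compound 2 `C=CCCCCOc1ncc(-c2cc(Cl)ccc2OC)n1C`, gives 28000 nM on the same scale of this assay where a higher number means weaker inhibition.

The unmeasured compound 3 `C=CCCCCOc1ncc(-c2ccc(Cl)cc2OC)n1C` differs from compound 1 by chloro in place of hydrogen on an aromatic carbon and the new chloro stands meta to a methoxy group and para to a large group. Among the measured compounds shown here, only one measured step bears on this change: the same exchange of hydrogen for chloro on an aromatic carbon, made at another place. That step is a 7.0-fold higher number from compound 1 to compound 2 (0.85 log units; beyond the scatter) and it points towards weaker inhibition. A single step at a different place is thin evidence, so a change in the same direction but of smaller size is expected in this assay for this exchange. The estimated step is a 2.3-fold higher number from compound 1 to compound 3 (0.35 log units; beyond the scatter) and it remains uncertain. For compound 3 the expected value is 9000 nM with an estimated range from 2500 nM to 30000 nM in this measurement.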

Compound 3, half-maximal inhibitory concentration: 35000 nM
The estimate for compound 3 lay 3.9-fold (0.59 log units) below the measured number; the measured number lies above the stated range.
By their numbers in this assay, from the lowest: compound 1; then compounds 2 and 3 (each within the scatter of the next).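

In this assay, chloro placed meta to a methoxy group and para to a large group also gives a higher number, an 8.8-fold higher number from compound 1 to compound 3 (0.94 log units; beyond the scatter), and so weaker inhibition. Among these compounds, until now, the loss of inhibition on adding chloro had been seen at only one place on this ring; it now appears at two, and compounds 2 and 3 lie within the scatter of each other, so in this pair the chloro's place makes no clear difference to the number. Nothing shown here explains why chloro in place of hydrogen weakens inhibition at this position.

Still open, from the compounds shown here alone, is whether the loss belongs to chloro itself or would also appear with other groups at this position, such as fluoro, methyl, an amine or a carboxylic acid. The compounds shown also leave open whether the same chloro step would hold on a core carrying a shorter or longer chain in place of the one shared by compound 1 and compound 3.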